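Hydroxy addition on two hydrazone cores

The source may hold more compounds than are shown below. What is called first, only, known or untested is meant among the compounds shown, and "the series" means these compounds.

Working notes on the series. Compound 2 `COc1cc(/C=N/NC(=O)OCc2ccccc2)ccc1O` and compound 1 `COc1cc(/C=N/NC(=O)OCc2ccccc2)cc(O)c1O` share one core. In a physicochemical assay on cells (Homo sapiens), with a stated time of 18 h, tested at 10 uM (a lower number here means a stronger effect, a higher number a weaker effect of the compound at the concentration tested), compound 2 gives 36%, and compound 1 gives 2%. The change between them is hydroxy in place of hydrogen on an aromatic carbon and the step it made is a number 34 percentage points lower from compound 2 to compound 1 (beyond the scatter). Compound 3 `COc1cc(/C=N/Nc2nc3ccccc3s2)ccc1O` is built on a different core; the difference between the two cores is not broken down here. In this assay compound 3 gives 7%, a number lower than that of compound 2 beyond the scatter, and within the scatter of the number of compound 1.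

Compound 4 `COc1cc(/C=N/Nc2nc3ccccc3s2)cc(O)c1O` is not yet measured in this assay. It differs from compound 3 by hydroxy in place of hydrogen on an aromatic carbon, the same change as from compound 2 to compound 1, set in the same surroundings. The earlier step of a number 34 percentage points lower from compound 2 to compound 1 (beyond the scatter) was large, but the pair it came from started high, whereas compound 3 already gives 7%, a number so small that a fall of that size cannot be repeated from it. The expected step is therefore small, a number 4 percentage points lower from compound 3 to compound 4 (within the scatter), beside the earlier one a number 34 percentage points lower from compound 2 to compound 1 (beyond the scatter). On that reasoning compound 4 is expected to give about 3% in this assay, most likely between 0% and 12%.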

Compound 4, a percentage reported as activity, at one concentration (the size of the read-out at that concentration, not a potency): 7%
Compound 4: middle estimate off by 4 percentage points, on the low side; measured number inside the range.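

In this assay, hydroxy in place of hydrogen on an aromatic carbon gives a number 34 percentage points lower from compound 2 to compound 1 (beyond the scatter) on the first core, while the same change on the second core gives no change at the digits printed from compound 3 to compound 4 (within the scatter), so the size of the step did not carry from one core to the other. This does not show that the change is without effect on the second core: compound 3 already gives 7% in this assay, which leaves very little room for a lower number, and a step of the earlier size could not have been seen from there. Nothing at hand bears on why the two steps differ.

The compounds shown leave open whether the second core would answer to the added hydroxy in a pair that starts from a higher number, since the only pair on this core starts near the bottom of the read-out. They also leave open what other groups do at the same place on the ring, ortho to a hydroxy group, such as an amine or a carboxylic acid in place of the added hydroxy.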